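This account rests on a few compounds, and the source may have more. Where it says the series, first, only, none or still open, it means among the compounds named here.

Measured compounds in a functional assay on OVCAR-5 cells (Homo sapiens) for inhibition, read by sulforhodamine B assay, with a stated time of 48 h, tested at 10 uM; on this read-out higher numbers stand for more inhibition at the one concentration tested (going by the name of the read-out) and lower numbers for less inhibition:

- compound 1, `Brc1cn2ccnc2c(-c2ccc3ncn(C4CCCCC4)c3c2)n1`: 6.64%
- compound 2, `Clc1ccc(-c2cn3ccnc3c(-c3ccc4ncn(C5CCCCC5)c4c3)n2)cc1`: 0.84%

Compound 2 sits at the lowest of the two numbers in this assay; its nearest neighbour is compound 1, and the gap between them is within the scatter, so no order between the two can be read off. For the measured compounds named here, the only step measured is a number 5.8 percentage points lower from compound 1 to compound 2 (within the scatter), a change within the scatter, and it describes a bromo-to-aryl exchange rather than one aryl for another.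

Compound 3, `COc1ccccc1-c1cn2ccnc2c(-c2ccc3ncn(C4CCCCC4)c3c2)n1`, is the next member. Its change from compound 2 is 2-methoxyphenyl in place of 4-chlorophenyl on an aromatic carbon. Going by the values given here, no measured step bears directly on an exchange of one six-membered aromatic ring of carbon only for another at this position; the one measured step is within the scatter and both measured numbers are low. The expectation is therefore no movement beyond the scatter, with an estimated step of a number 3.2 percentage points higher from compound 2 to compound 3 (within the scatter). For compound 3 in this assay the estimate is 4%, with a range from -6% to 15%.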

Compound 3, a percentage reported as inhibition, at one concentration (the size of the read-out at that concentration, not a potency): 6.61%
Estimate against measurement, compound 3: 2.6 percentage points below, within the range that was stated.
By their numbers in this assay, from the lowest: compounds 2, 3 and 1 (each within the scatter of the next).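

In this assay, the exchange of one aryl group for another at this position gives a number 5.8 percentage points higher from compound 2 to compound 3 (within the scatter), so 2-methoxyphenyl and 4-chlorophenyl are not separated, despite the hydrogen-bond acceptor counted in the entering group. The comparison with the smaller bromo gives a number 0 percentage points lower from compound 1 to compound 3 (within the scatter), and with the earlier step this places bromo, 4-chlorophenyl and 2-methoxyphenyl all within the scatter of one another, with no order among the three compounds on this read-out. Nothing available accounts for this lack of separation at the carbon para to a fused ring.

Still open, as far as these compounds go, is whether an amine, a carboxylic acid or a longer chain at this position would give a number beyond the scatter of compound 1, compound 2 and compound 3. Also open, from the compounds shown here alone, is whether changes elsewhere on the shared core would move the read-out, since all three compounds carry that core unchanged and differ only at this one carbon.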